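The source may hold more compounds than are shown below. What is called first, only, known or untested is meant among the compounds shown, and "the series" means these compounds.

Measured so far in an ADME assay on KB cells (Homo sapiens) for cytotoxicity, read by MTT assay, with a stated time of 72 h; a lower number here means a stronger inhibitor, a higher number a weaker inhibitor:
- compound 1 `COC(=O)c1cc(C2=C(c3cc(OC)c(OC)c(OC)c3)C(=O)CC2O[SiH2]C(C)(C)C)ccc1OC`: > 100 ug/mL
- compound 2 `COc1ccc(C2=C(c3cc(OC)c(OC)c(OC)c3)CC(O[SiH2]C(C)(C)C)C2=O)cc1[N+](=O)[O-]`: > 100 ug/mL

Compound 1 stands at > 100 ug/mL, which is a limit of the assay and not a number. Compound 2 shares that position: the limit of > 100 ug/mL in this assay, at which 2 of the 2 values shown sit.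

Compound 3 `COc1cc(C2=C(c3cc(C)c(OC)c(C)c3)C(O[SiH2]C(C)(C)C)CC2=O)cc(OC)c1OC` carries 4-methoxy-3,5-dimethylphenyl in place of 4-methoxy-3-(methoxycarbonyl)phenyl on a double-bonded ring carbon. Among the measured compounds shown here, no measured pair shows what this swap does in this assay. The expected a number no higher from compound 1 to compound 3 (the limit leaves the size open) is none beyond the usual scatter, in either direction. For compound 3 the estimated value is 100 ug/mL, with an expected range of 25 ug/mL to 200 ug/mL.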

Compound 3, half-maximal inhibitory concentration: 40 ug/mL
Compound 3: the middle estimate sits 2.5-fold (0.40 log units) above what was measured; low and high end bracket the measured number.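

In this assay, 4-methoxy-3,5-dimethylphenyl in place of 4-methoxy-3-(methoxycarbonyl)phenyl on a double-bonded ring carbon gives an at least 2.5-fold lower number from compound 1 to compound 3 (0.39 log units; beyond the scatter), so the read-out does respond to the group at this position. Among the compounds shown here, compound 3 is the first compound here with a measured number and not a limit. The full size of the step cannot be read because compound 1 stands at a limit: the limit of > 100 ug/mL in this assay, at which 2 of the 3 values shown sit.

The compounds shown do not separate the loss of the methoxycarbonyl group from the arrival of the methyl groups. From the compounds shown here alone, what an amine or a carboxylic acid on this ring would do also remains open.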